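Compound 1 and the unmeasured compound 3

The source may hold more compounds than are shown below. What is called first, only, known or untested is meant among the compounds shown, and "the series" means these compounds.

Measured in an ADME assay on HEK293 cells (Homo sapiens) for cytotoxicity, read by reporter gene assay and resazurin assay, with a stated time of 48 h (a higher number here means that more compound is tolerated, a lower number that less compound is tolerated), so far
- compound 1 `O=C(Nc1ccc(Sc2nc3ccccc3s2)c(Cl)c1)c1cc(Br)cc(Br)c1O` gives 76000 nM
- compound 2 `O=C(Nc1ccc(Sc2nc3ccccc3s2)cc1)c1cc(Br)cc(Br)c1O` gives 66000 nM

Compound 1 has a single measured neighbour, and the two values lie within the scatter of each other, so neither ranks above the other. Within the data shown here, the only measured step is a 1.2-fold lower number from compound 1 to compound 2 (0.06 log units; within the scatter), with hydrogen in place of chloro on an aromatic carbon.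

Compound 3 `COc1ccc(Br)cc1C(=O)Nc1ccc(Sc2nc3ccccc3s2)c(Cl)c1` differs from compound 1 on a carbonyl carbon (5-bromo-2-methoxyphenyl in place of 3,5-dibromo-2-hydroxyphenyl on a carbonyl carbon). Among the measured compounds shown here, the measured step concerns another part of the molecule, and no measured pair shows a change at this place. It gives only weak guidance, so no step beyond the scatter is expected in this assay, and the range is kept wide.

The expected step is a 1.1-fold higher number from compound 1 to compound 3 (0.02 log units; within the scatter).

Compound 3 is estimated at 80000 nM, with an expected range of 30000 nM to 200000 nM.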

Compound 3, half-maximal cytotoxic concentration: > 100000 nM
Compound 3 gave a limit, no number; the forecaster's own chance of this, stated with the estimate: 30%; middle value at least 1.2-fold (0.09 log units) away from the limit.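

In this assay compound 3 gives > 100000 nM, a limit of the assay and not a number. Among these compounds, this is the first reading at the carbonyl carbon: 5-bromo-2-methoxyphenyl in place of 3,5-dibromo-2-hydroxyphenyl gives an at least 1.3-fold higher number from compound 1 to compound 3 (0.11 log units; that floor lies within the scatter), so the group with 0 hydrogen-bond donors and one bromine fewer shows no loss of tolerated compound here. Going by these compounds, only a floor can be given for this step, and its true size stays unknown, because the reading stops at the limit: the limit of > 100000 nM in this assay, at which 1 of the 3 values shown sits.

The compounds shown do not separate the methyl on the oxygen from the missing bromine, as both change together in compound 3. On these data alone, how an amine or a carboxylic acid on this ring would read in this assay also remains open.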